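Bromo to nitro exchange in two related pairs

A few compounds are considered here, and "the series" means these few. Any claim that something is new, unique, unknown or untested is made for them only; others in the source may bear on it.

Of the compounds shown here, three have been tested in a functional assay on MCF7 cells (Homo sapiens) for inhibition, read by sulforhodamine B assay, with a stated time of 48 h; a lower number here means a stronger inhibitor of growth, a higher number a weaker inhibitor of growth. Compound 1 `N#CCC1=NN=C(c2ccc(Br)cc2)C(CC(=O)c2ccc(Br)cc2)O1` gives 30400 nM, while compound 3 `N#CCC1=NN=C(c2ccc([N+](=O)[O-])cc2)C(CC(=O)c2ccc(Br)cc2)O1` gives 36000 nM. Compound 3 differs from compound 1 in one place (nitro in place of bromo on an aromatic carbon), and that change produced a 1.2-fold higher number from compound 1 to compound 3 (0.07 log units; within the scatter). Compound 2 `N#CCC1=NN=C(c2ccc(Br)cc2)C(Br)O1` gives 70700 nM in this assay; the difference between its core and the core of compound 1 is not broken down here. Compound 4 `N#CCC1=NN=C(c2ccc([N+](=O)[O-])cc2)C(Br)O1` has not yet been measured; it differs from compound 2 by the same change (nitro in place of bromo on an aromatic carbon). A step of similar size is expected from compound 2 to compound 4, namely a 1.2-fold higher number from compound 2 to compound 4 (0.08 log units; within the scatter), because the earlier pair showed a 1.2-fold higher number from compound 1 to compound 3 (0.07 log units; within the scatter). Compound 4 is therefore estimated at 85000 nM, with a likely range from 40000 nM to 180000 nM.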

Compound 4, concentration for 50% growth inhibition: 10600 nM
For compound 4 the middle estimate is 8.0-fold (0.90 log units) above the measured one, outside the stated range (below it).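

Nitro in place of bromo on an aromatic carbon gives a 6.7-fold lower number from compound 2 to compound 4 (0.82 log units; beyond the scatter) in this assay on this core, so the change is not neutral here. The size of the step does not carry over from one core to the other: the same change on two cores in this assay, a 1.2-fold higher number (0.07 log units; within the scatter) from compound 1 to compound 3 and a 6.7-fold lower number (0.82 log units; beyond the scatter) from compound 2 to compound 4, 7.9-fold (0.90 log units) apart, beyond the scatter of two such steps. This does not show which part of the core sets the difference, and two pairs give no rule for the rest of the series.

The compounds shown carry only bromo or nitro at this place on the aromatic ring, so it stays open how an amine or a carboxylic acid there would behave on either core. Also open, from the compounds shown here alone, is how the same exchange would behave on a third core, with a longer chain where compound 1 and compound 2 differ.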